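The source may hold more compounds than are shown below. What is called first, only, known or untested is meant among the compounds shown, and "the series" means these compounds.

Measured so far:
Compound 1, `O=C1/C(=C/c2ccccc2Br)CCc2ccccc21`: 36800 nM
Compound 2, `O=C(/C=C/c1cccc([N+](=O)[O-])c1)c1ccccc1`: 8530 nM
Compound 3, `O=C1/C(=C/c2ccc(Cl)cc2Cl)CCCc2ccccc21`: > 500000 nM (a limit of the assay, not a number)

In a functional assay on Molt4/C8 cells (Homo sapiens) for inhibition (on this read-out higher numbers stand for weaker inhibition and lower numbers for stronger inhibition), compound 1 gives 36800 nM, the higher of the two numbers recorded. Compound 2 gives 8530 nM, a lower number that lies beyond the usual scatter. For compound 3 the assay reports only (the limit of > 500000 nM in this assay, at which 1 of the 3 values shown sits), so no number is known for it. Compound 4, `O=C1/C(=C/c2ccccc2[N+](=O)[O-])CCc2ccccc21`, differs from compound 1 in one place: nitro in place of bromo on an aromatic carbon. Among the measured compounds shown here, no measured pair shows this same change, so its size is uncertain. A modest move toward a lower number is expected, as a 1.8-fold lower number from compound 1 to compound 4 (0.26 log units; within the scatter). For compound 4 the estimate is 20000 nM, with a range from 6000 nM to 70000 nM.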

Compound 4, half-maximal inhibitory concentration: 8120 nM
Estimate against measurement, compound 4: 2.5-fold (0.39 log units) above, and the stated range covers the measured number.
By their numbers in this assay, from the lowest: compounds 4 and 2 (each within the scatter of the next); then compound 1. At a limit, above all of these: compound 3.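

In this assay the change from bromo to nitro on this aromatic carbon, ortho to a large group, gives a 4.5-fold lower number from compound 1 to compound 4 (0.66 log units; beyond the scatter) and so shows that the choice of group at this position affects the number. Among the compounds shown here, the earlier compounds held no pair differing in one place, so this is the only change that can be read on its own. No measurement shown speaks to why the step occurs. The compounds shown leave open what an amine or a carboxylic acid on this carbon would give, and whether nitro elsewhere on the ring would give the same step.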